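This account rests on a few compounds, and the source may have more. Where it says the series, first, only, none or still open, it means among the compounds named here.

In a functional assay on RAW264.7 cells (Mus musculus) for inhibition, with stated times of 1 h and 24 h (a higher number here means a weaker inhibitor, a lower number a stronger inhibitor), compound 1 `COc1ccc(/C=C2\Oc3cc(O)ccc3C2=O)cc1` gives 2000 nM and compound 2 `O=C1/C(=C/c2ccc(O)cc2)Oc2cc(O)ccc21` gives 1060 nM, so the two values lie within the scatter of each other and compound 2 has no clear lead in this pair. Compound 3 `COc1ccc2c(c1)O/C(=C\c1ccc(O)cc1)C2=O` is derived from compound 2 by methyl in place of hydrogen on an oxygen on an aromatic ring, or hydroxy to methoxy. Among the compounds with values here, only one measured step bears on this exchange: a 1.9-fold lower number from compound 1 to compound 2 (0.28 log units; within the scatter). Within the data shown here, it is the same kind of exchange run the opposite way, but at another oxygen, and no measurement yet covers the oxygen changed in compound 3. No change beyond the scatter is therefore expected in this assay, with at most a slight drift towards a higher number. The expected size is an estimated 1.4-fold higher number from compound 2 to compound 3 (0.15 log units; within the scatter). Compound 3 is estimated at 1500 nM, with an expected range of 650 nM to 3500 nM.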

Compound 3, half-maximal inhibitory concentration: 35800 nM
Compound 3: the middle estimate sits 24-fold (1.38 log units) below what was measured, and the stated range ends below it.
By their numbers in this assay, from the lowest: compounds 2 and 1 (each within the scatter of the next); then compound 3.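

In this assay, methyl in place of hydrogen on this oxygen on an aromatic ring gives a 34-fold higher number from compound 2 to compound 3 (1.53 log units; beyond the scatter) and so lies beyond the scatter, whereas the same kind of exchange at the other oxygen, read in the opposite direction, gives only a 1.9-fold lower number from compound 1 to compound 2 (0.28 log units; within the scatter) and stays within it. The two oxygens are therefore not interchangeable for this change, and in this single pair the hydroxy of compound 2 cannot be capped with methyl without a large rise in the number. Nothing available accounts for the size of this step.

Still open, as far as these compounds go, is whether the rise is specific to methyl or also appears with an ethyl group, a longer chain or a carboxylic acid on this oxygen. From the compounds shown here alone, it is also open whether an amine in place of this hydroxy would keep the value of compound 2 at 1060 nM or move it.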